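The compounds below may be only part of what the source reports. "The series", "measured", "known", "first", "only" and "open" are said of these compounds alone.

In an assay on CHO-K1 cells for antagonist activity at transient receptor potential cation channel subfamily V member 1 (Homo sapiens), read by FLIPR and calcium flux, with a stated time of 6 min (on this read-out higher numbers stand for weaker inhibition and lower numbers for stronger inhibition), the measured compounds read: compound 1 `Cn1ncc2c(NC(=O)NCc3cc(C(F)(F)F)nn3-c3cccc(Cl)c3)cccc21` at 2.3 nM; compound 2 `Cn1ncc2c(NC(=O)NCc3cc(C(F)(F)F)nn3-c3cccc(F)c3)cccc21` at 7 nM; compound 3 `Cn1ncc2c(NC(=O)NCc3cc(C(F)(F)F)nn3-c3ccc(Cl)cc3)cccc21` at 2.7 nM.

Compound 3 sits within the scatter of compound 1, as a 1.2-fold higher number from compound 1 to compound 3 (0.07 log units; within the scatter) shows, and clearly apart from compound 2, as a 2.6-fold lower number from compound 2 to compound 3 (0.41 log units; beyond the scatter) shows. Compound 4 `Cn1ncc2c(NC(=O)NCc3cc(C(F)(F)F)nn3-c3ccc(F)cc3)cccc21` differs from compound 3 by fluoro in place of chloro on an aromatic carbon. The same exchange has been made once already, and there it gave a 3.0-fold higher number from compound 1 to compound 2 (0.48 log units; beyond the scatter), a modest step beyond the scatter; the step of a 1.2-fold higher number from compound 1 to compound 3 (0.07 log units; within the scatter) suggests the shift of the substituent around the ring changes little. A modest weakening is therefore expected in this assay. Compound 4 is expected to give about 8 nM, between 3.5 nM and 20 nM, an expected 3.0-fold higher number from compound 3 to compound 4 (0.47 log units; beyond the scatter).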

Compound 4, inhibition constant: 8.4 nM
Estimate against measurement, compound 4: 1.1-fold (0.02 log units) below; the range from low to high includes it.
By their numbers in this assay, from the lowest: compounds 1 and 3 (each within the scatter of the next); then compounds 2 and 4 (each within the scatter of the next).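

On the 4-chlorophenyl compound, fluoro in place of chloro gives a 3.1-fold higher number from compound 3 to compound 4 (0.49 log units; beyond the scatter), so the loss seen on the 3-chlorophenyl compound is not confined to that substitution pattern. Among the fluoro compounds, moving to 4-fluorophenyl from 3-fluorophenyl gives a 1.2-fold higher number from compound 2 to compound 4 (0.08 log units; within the scatter), while the step that changes both halogen and position gives a 3.7-fold higher number from compound 1 to compound 4 (0.56 log units; beyond the scatter). The halogen, not its position, thus separates these four compounds, and the exchange repeats closely: the same change on two cores in this assay, a 3.0-fold higher number (0.48 log units; beyond the scatter) from compound 1 to compound 2 and a 3.1-fold higher number (0.49 log units; beyond the scatter) from compound 3 to compound 4, 1.0-fold (0.01 log units) apart, within the scatter of two such steps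

The compounds shown leave open whether a methyl, a methoxy or an amine at this place would read closer to chloro or to fluoro. They also leave open how the unsubstituted phenyl would compare.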